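Halogen swap on a shared chalcone core: compound 4 outlook

The source may report more compounds than this note shows. Statements on the series, on what has been measured and on what is new or still open speak of the compounds shown alone.

Measured so far in a functional assay on MCF7 cells (Homo sapiens) for antiproliferative activity, read by MTT assay, with a stated time of 48 h; a lower number here means a stronger inhibitor, a higher number a weaker inhibitor:
compound 1, `Cc1ccc(C(=O)/C=C/c2cccc(Br)c2Oc2c([N+](=O)[O-])cc(C(F)(F)F)cc2[N+](=O)[O-])cc1`, gives 0.55 ug/mL
compound 2, `Cc1ccc(C(=O)/C=C/c2cccc(Cl)c2Oc2c([N+](=O)[O-])cc(C(F)(F)F)cc2[N+](=O)[O-])cc1`, gives 0.03 ug/mL
compound 3, `O=C(/C=C/c1cccc(Br)c1Oc1c([N+](=O)[O-])cc(C(F)(F)F)cc1[N+](=O)[O-])c1ccc(Cl)cc1`, gives 4.74 ug/mL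

Two changes have been measured. The first is chloro in place of bromo on an aromatic carbon, and it made an 18-fold lower number from compound 1 to compound 2 (1.26 log units; beyond the scatter). The second is chloro in place of methyl on an aromatic carbon, and it made an 8.6-fold higher number from compound 1 to compound 3 (0.94 log units; beyond the scatter). Compound 3 thus carries the highest number of the three, and compound 2 the lowest, both beyond the scatter from the others.

Compound 4, `O=C(/C=C/c1cccc(Cl)c1Oc1c([N+](=O)[O-])cc(C(F)(F)F)cc1[N+](=O)[O-])c1ccc(Cl)cc1`, is not yet measured. Its difference from compound 3 is chloro in place of bromo on an aromatic carbon. Among the compounds with values here, this is the same kind of change as the one from compound 1 to compound 2, but not the same: in compound 3 the place is meta to a 2-((4-chlorophenyl)carbonyl)ethenyl group, whereas in compound 1 it is meta to a 2-((4-methylphenyl)carbonyl)ethenyl group. How the two cores differ is given by chloro in place of methyl on an aromatic carbon.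

Within the data shown here, only one measured instance of the halogen swap exists, so whether its size carries over to the other core is unknown. The expectation for compound 4 in this assay is a step of about a 9.5-fold lower number from compound 3 to compound 4 (0.98 log units; beyond the scatter), somewhat smaller than the measured one, because that measured step an 18-fold lower number from compound 1 to compound 2 (1.26 log units; beyond the scatter) stands alone and may not repeat in full. Compound 4 is therefore estimated at 0.5 ug/mL, expected to lie between 0.1 ug/mL and 2.5 ug/mL.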

Compound 4, half-maximal inhibitory concentration: 3.21 ug/mL
The estimate for compound 4 lay 6.4-fold (0.81 log units) below the measured number; measured number above the stated range.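

In this assay, chloro in place of bromo gives a 1.5-fold lower number from compound 3 to compound 4 (0.17 log units; within the scatter), so the large drop in the number seen on the other core does not repeat here: the same change on two cores in this assay, an 18-fold lower number (1.26 log units; beyond the scatter) from compound 1 to compound 2 and a 1.5-fold lower number (0.17 log units; within the scatter) from compound 3 to compound 4, 12-fold (1.09 log units) apart, beyond the scatter of two such steps. Read along the other direction, chloro in place of methyl gives a 110-fold higher number from compound 2 to compound 4 (2.03 log units; beyond the scatter), and the size of this step likewise differs with the halogen present at the other place: the same change on two cores in this assay, an 8.6-fold higher number (0.94 log units; beyond the scatter) from compound 1 to compound 3 and a 110-fold higher number (2.03 log units; beyond the scatter) from compound 2 to compound 4, 12-fold (1.09 log units) apart, beyond the scatter of two such steps. The two changes therefore do not add independently across these four compounds, but this single set of four shows only that the size of each step depends on the other place, and it offers neither a cause nor a rule for any further core.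

As far as these compounds go, it remains open whether the low number of compound 2, at 0.03 ug/mL, is particular to the pairing of methyl with chloro or would also appear with a methoxy group or an ethyl group in place of that methyl. Also open, from the compounds shown here alone, is how fluoro or a nitrile in place of bromo would behave on either core, and whether an amine or a carboxylic acid in place of methyl would follow compound 2 or compound 4.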